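This account rests on a few compounds, and the source may have more. Where it says the series, first, only, none or still open, it means among the compounds named here.

Working notes on the series. The only read-out is a functional assay on CFPAC-1 cells (Homo sapiens) for antiproliferative activity, read by MTT assay, with a stated time of 72 h; a lower number here means a stronger inhibitor, a higher number a weaker inhibitor. Going by the values given here, compound 1 `O=C1O[C@H]([C@@H](O)Cn2cc(CNS(=O)(=O)c3ccc(Cl)cc3F)nn2)C(OCc2ccccc2)=C1OCc1ccccc1` gives 58200 nM in this assay, and that is the sole number in the set. Compound 2 `CCCCCc1ccc(-c2cn(C/C=C3\OC(=O)C(OCc4ccccc4)=C3OCc3ccccc3)nn2)cc1` is reported only as a limit, namely > 100000 nM in this assay. The picture so far is therefore one measured point and (the limit of > 100000 nM in this assay, at which 1 of the 2 values shown sits). Compound 1 is the reference for the step considered here. Compound 3 `O=C1O[C@H]([C@@H](O)Cn2cc(CNS(=O)(=O)c3ccc(Cl)cc3)nn2)C(OCc2ccccc2)=C1OCc1ccccc1` differs from compound 1 by hydrogen in place of fluoro on an aromatic carbon. No measured neighbours separated by one change exist to calibrate such a step, and the fluoro is a single heavy atom on an aromatic carbon, so the step is expected to be small, none beyond the scatter, in either direction. The expected step is a 1.0-fold higher number from compound 1 to compound 3 (0.01 log units; within the scatter). Compound 3 is accordingly estimated at 60000 nM in this assay. The expected range for compound 3 runs from 25000 nM to 150000 nM. A reported limit instead of a number remains possible for compound 3.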

Compound 3, half-maximal inhibitory concentration: 38900 nM
For compound 3 the middle estimate is 1.5-fold (0.19 log units) above the measured one; the measured number falls inside the stated range.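

Going by these compounds alone, the change from 4-chloro-2-fluorophenyl to 4-chlorophenyl gives the first one-place step, and in this assay it is a 1.5-fold lower number from compound 1 to compound 3 (0.17 log units; within the scatter). For this aromatic carbon, ortho to a large group, this single pair therefore shows no difference between fluoro and hydrogen that can be told from the scatter. The compounds shown give no measured basis for assigning a cause to this step.

Going by these compounds, whether a methoxy, a trifluoromethyl or an amine on the same carbon would move the number beyond the scatter remains open. Also open, on these data alone, is whether replacing the chloro group of the 4-chlorophenyl, for example with a methyl or a nitrile, would change the number in this assay.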